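Bicyclic amide swap on the sulfonylbenzyl amide series

The source may report more compounds than this note shows. Statements on the series, on what has been measured and on what is new or still open speak of the compounds shown alone.

Compound 1 `O=C(NCc1ccc(S(=O)(=O)c2ccccc2)cc1)c1cc2ccncc2s1` gives 7 nM in an assay for inhibition of Nicotinamide phosphoribosyltransferase (Homo sapiens), read by mass spectrometry, with stated times of 15 min and 30 min; on this read-out higher numbers stand for weaker inhibition and lower numbers for stronger inhibition. Compound 2 `CC(NC(=O)c1cc2cnccc2[nH]1)c1ccc(S(=O)(=O)N2CCCCC2)cc1` returns only a limit, > 10000 nM, in this assay. Among the compounds with values here, compound 3 `O=C(NCc1ccc(S(=O)(=O)c2ccccc2)cc1)c1nc2cnccc2[nH]1` gives 7100 nM in this assay and so stands with the highest of the two numbers; the only measured step that reaches it is a 1000-fold higher number from compound 1 to compound 3 (3.01 log units; beyond the scatter), which shows that the group on the carbonyl carbon governs the number strongly. Compound 4 `O=C(NCc1ccc(S(=O)(=O)c2ccccc2)cc1)c1cn2ccnc2cn1` differs from compound 3 by a group of 9 heavy atoms (6 carbon, 3 nitrogen; one five-membered aromatic ring with 2 hetero atoms, one six-membered aromatic ring with 2 hetero atoms) in place of a group of 9 heavy atoms (6 carbon, 3 nitrogen; one five-membered aromatic ring with 2 hetero atoms, one six-membered aromatic ring with 1 hetero atom), on a carbonyl carbon. Within the data shown here, no measured step repeats this change, so the direction must be judged from the sensitivity seen in a 1000-fold higher number from compound 1 to compound 3 (3.01 log units; beyond the scatter) alone. Compound 4 is expected to give a lower number, estimated at 150 nM within 10 nM to 3000 nM, a step of a 47-fold lower number from compound 3 to compound 4 (1.68 log units; beyond the scatter).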

Compound 4, half-maximal inhibitory concentration: 150 nM
Compound 4: the middle estimate sits on the measured number at the digits printed; measured number inside the range.
By their numbers in this assay, from the lowest: compound 1; then compound 4; then compound 3. At a limit, above all of these: compound 2.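

In this assay, the group on the carbonyl carbon governs the number even with the atoms unchanged: a 47-fold lower number from compound 3 to compound 4 (1.68 log units; beyond the scatter), as the entering group carries 0 hydrogen-bond donors and 3 hydrogen-bond acceptors. The recovery is only partial, since a 21-fold higher number from compound 1 to compound 4 (1.33 log units; beyond the scatter), so the group holding sulfur still gives the lowest number. Nothing available bears on the reason for either step. Still open, on these data alone, is whether the donor count or the acceptor count drives the first step, since the two change together. Also open, as far as these compounds go, is how a methyl group or an amine on the entering group would read.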